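The source may hold more compounds than are shown below. What is called first, only, known or untested is meant among the compounds shown, and "the series" means these compounds.

Compound 1 `CC(CO)NC(=O)/C=C/c1ccccc1` gives 89% in a toxicity assay on HepG2 cells (Homo sapiens) for cytotoxicity, read by trypan blue exclusion, with a stated time of 24 h, tested at 100 uM (on this read-out higher numbers stand for a weaker effect at the one concentration tested and lower numbers for a stronger effect), and stands level with compound 2 `CCC(O)CNC(=O)/C=C/c1ccccc1`, which gives 89% in this assay. Among the measured compounds shown here, the only recorded step, no change at the digits printed from compound 1 to compound 2 (within the scatter), exchanges one hydroxyalkyl group for another on the amide-type nitrogen. Compound 3 `CC(C)C(CO)NC(=O)/C=C/c1ccccc1` differs from compound 1 by isopropyl in place of methyl on a saturated chain carbon bound to an amide-type nitrogen and a saturated chain carbon. For the measured compounds named here, no recorded step alters a group on the saturated chain carbon bound to the amide-type nitrogen; the nearest comparison, no change at the digits printed from compound 1 to compound 2 (within the scatter), shows no change within the scatter. No step beyond the scatter is therefore expected in this assay, with a number 1 percentage points lower from compound 1 to compound 3 (within the scatter). Compound 3 is expected to give 88%, in the range 76% to 98%.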

Compound 3, a percentage reported as activity, at one concentration (the size of the read-out at that concentration, not a potency): 90%
Compound 3: the middle estimate sits 2 percentage points below what was measured; the measured number falls inside the stated range.
By their numbers in this assay, from the lowest: compounds 1, 2 and 3 (each within the scatter of the next).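

Isopropyl in place of methyl on a saturated chain carbon bound to an amide-type nitrogen and a saturated chain carbon is the first recorded change at this position, and in this assay it gives a number 1 percentage points higher from compound 1 to compound 3 (within the scatter). The read-out therefore shows no step beyond the scatter for this exchange of alkyl groups, whereas the earlier step covered only an exchange of one hydroxyalkyl group for another. No measurement bears on the reason for this result. Going by these compounds, whether an amine, a carboxylic acid or a longer chain at this position would give a comparable reading remains open.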